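Compound 2 to compound 3: changing the side chain

A few compounds are considered here, and "the series" means these few. Any claim that something is new, unique, unknown or untested is made for them only; others in the source may bear on it.

In a functional assay on MX1 cells (Homo sapiens) for inhibition, read by MTT assay, with a stated time of 120 h (a lower number here means a stronger inhibitor, a higher number a weaker inhibitor), compound 1 (`C/C(=C\c1ccc(NC(=O)Nc2ccc(Cl)c(C(F)(F)F)c2)cc1)C(=O)NC(C)c1ccccc1`) gives > 50000 nM, which is a limit and not a number. Compound 2 (`CNC(=O)/C(C)=C/c1ccc(NC(=O)Nc2ccc(Cl)c(C(F)(F)F)c2)cc1`) gives > 50000 nM in this assay, again a limit, so its standing is known only as a limit. Both values shown sit at the same point: the limit of > 50000 nM in this assay, at which 2 of the 2 values shown sit. Compound 3 (`CNC(=O)CCc1ccc(NC(=O)Nc2ccc(Cl)c(C(F)(F)F)c2)cc1`) has 2-(methylcarbamoyl)ethyl in place of 2-(methylcarbamoyl)prop-1-en-1-yl on an aromatic carbon, para to a large group: 2-(methylcarbamoyl)ethyl in place of 2-(methylcarbamoyl)prop-1-en-1-yl on an aromatic carbon. Within the data shown here, the one measured step, a step that the two limits leave unreadable from compound 1 to compound 2, offers no size to carry over, and no measured step covers this change. No step beyond the scatter is therefore expected in this assay, in either direction. The step expected is a number no higher from compound 2 to compound 3 (the limit leaves the size open). For compound 3 the estimated value is 50000 nM, with an expected range of 20000 nM to 80000 nM.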

Compound 3, half-maximal inhibitory concentration: 20400 nM
Compound 3: middle estimate off by 2.5-fold (0.39 log units), on the high side; low and high end bracket the measured number.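

In this assay, among these compounds, 2-(methylcarbamoyl)ethyl in place of 2-(methylcarbamoyl)prop-1-en-1-yl on an aromatic carbon, para to a large group, gives an at least 2.4-fold lower number from compound 2 to compound 3 (0.38 log units; beyond the scatter) and is the first step with a readable size. The side chain at this place can therefore bring a compound off the limit, with one heavy atom and one double bond fewer and the hydrogen-bond donor and acceptor counts unchanged. Among the compounds shown here, the step from compound 1 to compound 2 cannot be read, and the earlier compounds give only a limit and no number: the limit of > 50000 nM in this assay, at which 2 of the 3 values shown sit.

The compounds shown do not separate the loss of the double bond from the loss of the methyl on the chain. From the compounds shown here alone, how a carboxylic acid, an amine or a longer chain at this place would read remains open.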